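A few compounds are considered here, and "the series" means these few. Any claim that something is new, unique, unknown or untested is made for them only; others in the source may bear on it.

Compound 1 `O=S(=O)(Nc1ccc(-c2nc3ccccc3o2)cc1)c1cccs1` gives > 63000 nM in an assay on isolated protein for inhibition of malate dehydrogenase, mitochondrial (Sus scrofa), with stated times of 45 min and 30 min; on this read-out higher numbers stand for weaker inhibition and lower numbers for stronger inhibition.
Compound 2 `O=S(=O)(Nc1ccc2oc(-c3ccccc3)nc2c1)c1ccccc1Cl` gives > 63000 nM in this assay.
Compound 3 `O=S(=O)(Nc1ccc2oc(-c3ccccc3)nc2c1)c1ccc(Cl)c(Cl)c1` gives > 63000 nM in this assay.

Each of these three values is a limit of the assay and not a number. Compound 1 therefore stands at the limit, and nothing on the numbers shown places it above or below compound 2 or compound 3. Among the measured compounds shown here, the only step between measured compounds that differ in one place is the one from compound 2 to compound 3, a step that the two limits leave unreadable from compound 2 to compound 3, and it concerns a swap on the sulfonyl sulfur of a different core than that of compound 1. The change now followed, (4-methoxyphenyl in place of thiophen-2-yl on a sulfonyl sulfur), gives compound 4 `COc1ccc(S(=O)(=O)Nc2ccc(-c3nc4ccccc4o3)cc2)cc1`. For the measured compounds named here, no measured step touches this exchange of a thiophen-2-yl for a 4-methoxyphenyl, so its size cannot be read from the data; what is known is the limit of > 63000 nM in this assay, at which 3 of the 3 values shown sit, and on that basis no reading beyond the scatter is expected in this assay for compound 4 either, in either direction. Compound 4 is expected to give about 100000 nM, with a range from 30000 nM to 400000 nM. The step this estimate implies, a step that the limit leaves unreadable from compound 1 to compound 4, is expected to stay within the scatter and most likely to end as a limit again.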

Compound 4, half-maximal inhibitory concentration: > 63000 nM
Compound 4 gave a limit, no number (the forecaster's own chance of this, stated with the estimate: 85%); the middle value is on the limit's open side.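

Among the compounds shown here, compound 1 and compound 4 both give only a limit, so the exchange of thiophen-2-yl for 4-methoxyphenyl on a sulfonyl sulfur yields no step that can be read. The compounds shown leave open how strongly any of them inhibits in this assay, and what any change on the sulfonyl sulfur does to that read-out: the limit of > 63000 nM in this assay, at which 4 of the 4 values shown sit.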